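Working notes: hydroxy for bromo, compound 1 to compound 3

The source may report more compounds than this note shows. Statements on the series, on what has been measured and on what is new or still open speak of the compounds shown alone.

Measured so far:
- compound 1 `C/C(=C\CC/C(C)=C/CC[C@@H]1[C@@]2(C)CCC(=O)C(C)(C)[C@H]2CC[C@@]1(C)O)CC/C=C(\C)C(=O)OCc1cn(-c2cccc(Br)c2)nn1` gives > 150000 nM in a functional assay on DU-145 cells (Homo sapiens) for antiproliferative activity, read by MTT assay, with a stated time of 48 h; on this read-out higher numbers stand for weaker inhibition and lower numbers for stronger inhibition; this is a limit of the assay, not a number.
- compound 2 `C/C(=C\CC/C(C)=C/CC[C@@H]1[C@@]2(C)CCC(=O)C(C)(C)[C@H]2CC[C@@]1(C)O)CC/C=C(\C)C(=O)OCc1cn(C[C@@H]2O[C@H](n3ccc(=O)[nH]c3=O)[C@H]3OC(C)(C)O[C@H]32)nn1` gives > 150000 nM in this assay; this too is a limit.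

Compound 1 therefore cannot be placed on a scale: it sits at the limit of > 150000 nM in this assay, at which 2 of the 2 values shown sit, and compound 2 sits at the same limit. Among the compounds with values here, the two measured compounds share the same ester-linked core and differ in the substituent on the triazole, but no step between compounds differing in one place is available, so no measured step size exists.

Compound 3 `C/C(=C\CC/C(C)=C/CC[C@@H]1[C@@]2(C)CCC(=O)C(C)(C)[C@H]2CC[C@@]1(C)O)CC/C=C(\C)C(=O)OCc1cn(-c2cccc(O)c2)nn1` differs from compound 1 by hydroxy in place of bromo on an aromatic carbon. No measured value speaks for or against this change. With compound 1 at a limit, the expected step in this assay is none beyond the scatter, and the expectation for compound 3 is that the assay again reports a limit rather than a number, with a step that the limit leaves unreadable from compound 1 to compound 3 expected as the step.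

Compound 3 is estimated at 200000 nM in this assay, with an expected range from 60000 nM to 600000 nM.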

Compound 3, half-maximal inhibitory concentration: 28400 nM
Compound 3: the middle estimate sits 7.0-fold (0.85 log units) above what was measured; measured number below the stated range.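

Hydroxy in place of bromo on the aromatic carbon gives the first readable change in this series, with an at least 5.2-fold lower number from compound 1 to compound 3 (0.72 log units; beyond the scatter) in this assay. Going by these compounds, compound 1 stands at > 150000 nM, which is a limit and not a number, so the step gives only a minimum size and its full size stays unknown. Compound 3 alone among the compounds shown leaves the limit, so exchanging one heavy atom at this place on the six-membered aromatic ring is enough to bring the series onto a readable scale: the limit of > 150000 nM in this assay, at which 2 of the 3 values shown sit.

Still open, on these data alone, is whether the step belongs to the entering hydroxy or to the departure of bromo, and whether the same exchange would count equally at another carbon of the ring. An amine, a methoxy or a carboxylic acid on the same aromatic carbon would separate these readings, and each would show whether the read-out moves further from the value of compound 3, 28400 nM, or stays within the usual scatter of it.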